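A few compounds are considered here, and "the series" means these few. Any claim that something is new, unique, unknown or untested is made for them only; others in the source may bear on it.

Working notes on the series. In a functional assay on CHO-K1 cells for antagonist activity at prostaglandin D2 receptor 2 (Homo sapiens), read by scintillation counting and GTPgammaS binding, with stated times of 1 h and 2 h (a higher number here means a weaker inhibitor, a lower number a stronger inhibitor), compound 1 `COc1c(CC(=O)O)c(C)nn1-c1cccc(NC(=O)[C@H]2C[C@@H]2c2ccccc2)c1` gives 1600 nM, while compound 2 `Cc1nn(Cc2ccccc2S(=O)(=O)c2ccccc2)c(C)c1CC(=O)O` gives 81 nM. For the measured compounds named here, compound 2 holds the lowest of the two numbers so far, and the gap to compound 1 lies beyond the scatter. Compound 3 `Cc1c(CC(=O)O)c(-c2ccc(Cl)cc2)nn1Cc1ccccc1S(=O)(=O)c1ccccc1` is not yet measured. It differs from compound 2 in one place: 4-chlorophenyl in place of methyl on an aromatic carbon. Going by the values given here, with no step of this kind among the measured pair, the change is expected to give a 1.4-fold lower number from compound 2 to compound 3 (0.13 log units; within the scatter) in this assay, and no shift beyond the scatter is expected. Compound 3 is therefore estimated at 60 nM, within a range of 15 nM to 250 nM.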

Compound 3, half-maximal inhibitory concentration: 24 nM
Beside the measured number, compound 3's estimate is 2.5-fold (0.40 log units) above it; measured number inside the range.
By their numbers in this assay, from the lowest: compound 3; then compound 2; then compound 1.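

In this assay, the aromatic carbon next to the ring nitrogen and next to the ring atom that bears a carboxymethyl group tolerates more than a methyl: 4-chlorophenyl there gives a 3.4-fold lower number from compound 2 to compound 3 (0.53 log units; beyond the scatter). The added six-membered aromatic ring therefore does not cost activity at this position, and the number falls beyond the scatter. Nothing on hand explains the step. Going by these compounds, how much of it belongs to the ring and how much to the chlorine remains open; a plain phenyl or a 4-methoxyphenyl at this carbon would separate the two.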